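This account rests on a few compounds, and the source may have more. Where it says the series, first, only, none or still open, it means among the compounds named here.

Compound 1 `Cc1ccc(Nc2nnc(Nc3nc(-c4ccc(Cl)cc4)cs3)s2)cc1` gives 300 mg/kg in a functional assay on the whole organism (strain albino) with Mus musculus as the target, in the maximal electroshock model, with a stated time of 0.5 h; a lower number here means that less compound is needed, a higher number that more compound is needed for the effect. Compound 2 `Cc1ccc(Nc2nnc(Nc3nc(-c4ccc(Br)cc4)cs3)s2)cc1` gives 100 mg/kg in this assay. Compound 3 `Cc1ccccc1Nc1nnc(Nc2nc(-c3ccc([N+](=O)[O-])cc3)cs2)s1` gives 100 mg/kg in this assay.

Compound 3 stands level with compound 2 at the digits given, and these two share the lowest number of the three; compound 1 sits furthest from compound 3. Among the measured compounds shown here, the one measured step, a 3.0-fold lower number from compound 1 to compound 2 (0.48 log units; beyond the scatter), concerns a halogen and does not touch the change now in question. Compound 4 `Cc1ccc(Nc2nnc(Nc3nc(-c4ccc([N+](=O)[O-])cc4)cs3)s2)cc1` differs from compound 3 by 4-methylphenyl in place of 2-methylphenyl on a nitrogen on an aromatic ring. For the measured compounds named here, no measured pair isolates this change, so there is no basis to expect a step beyond the scatter in this assay. Compound 4 is therefore estimated at 100 mg/kg, within 50 mg/kg to 300 mg/kg, which means an expected step of no change at the digits printed from compound 3 to compound 4 (within the scatter).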

Compound 4, minimum effective dose: 30 mg/kg
Compound 4: middle estimate off by 3.3-fold (0.52 log units), on the high side; the measured number lies below the stated range.
By their numbers in this assay, from the lowest: compound 4; then compounds 2 and 3 (each within the scatter of the next); then compound 1.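

In this assay, 4-methylphenyl in place of 2-methylphenyl on a nitrogen on an aromatic ring gives a 3.3-fold lower number from compound 3 to compound 4 (0.52 log units; beyond the scatter), so joining the same atoms differently changes the dose needed. With 4-methylphenyl kept, nitro in place of bromo gives a 3.3-fold lower number from compound 2 to compound 4 (0.52 log units; beyond the scatter), and nitro in place of chloro gives a 10-fold lower number from compound 1 to compound 4 (1.00 log units; beyond the scatter), so the group on the aromatic carbon counts as well. Nothing available explains either change. Still open, going by these compounds, is whether an amine or a carboxylic acid on that aromatic carbon would match nitro, and whether the 4-methylphenyl step holds with bromo or chloro there.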